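Moving a methyl group on the benzyl sulfide of compound 1

The compounds below may be only part of what the source reports. "The series", "measured", "known", "first", "only" and "open" are said of these compounds alone.

Measured compounds:
compound 1 `C#CCNC1CCc2c(SCc3cccc(C)c3)cccc21`: > 100000 nM
compound 2 `C#CCNC1CCc2c(SCCc3ccc(C(F)(F)F)cc3)cccc21`: 8780 nM
compound 3 `C#CCNC1CCc2c(SCc3ccc(F)cc3F)cccc21`: 1480 nM

These three compounds share one core and differ only in the group carried on the sulfur. In an ADME assay on isolated protein for inhibition of Amine oxidase [flavin-containing] B (Homo sapiens) (on this read-out higher numbers stand for weaker inhibition and lower numbers for stronger inhibition), compound 1 gives > 100000 nM, which is a limit of the assay rather than a number. Compound 1 thus stands at the weak end of what was measured; its value sits at the limit of > 100000 nM in this assay, at which 1 of the 3 values shown sits. Compound 2 gives 8780 nM and compound 3 gives 1480 nM, both measurable numbers.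

Compound 4 `C#CCNC1CCc2c(SCc3ccc(C)cc3)cccc21` has not yet been measured. It differs from compound 1 by 4-methylphenyl in place of 3-methylphenyl on a saturated chain carbon bound to a sulfur. Within the data shown here, no pair that differs in one place has been measured here, so the size of such a step is unknown. Since compound 1 shows only a limit, the step from compound 1 to compound 4 is expected to be a move toward stronger inhibition, of uncertain size, written as an at least 3.3-fold lower number from compound 1 to compound 4 (0.52 log units; beyond the scatter). Compound 4 is therefore expected to give about 30000 nM, within 5000 nM to 200000 nM.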

Compound 4, half-maximal inhibitory concentration: 320 nM
Compound 4: the middle estimate sits 94-fold (1.97 log units) above what was measured; the whole stated range lies above it.
By their numbers in this assay, from the lowest: compound 4; then compound 3; then compound 2. At a limit, above all of these: compound 1.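

Among these compounds, this is the first pair here that differs in one place, and it shows that the benzyl sulfide is highly sensitive to where its methyl group sits. In this assay, replacing 3-methylphenyl with 4-methylphenyl on the saturated chain carbon bound to the sulfur gives an at least 310-fold lower number from compound 1 to compound 4 (2.49 log units; beyond the scatter). The full size of this step cannot be read, since compound 1 gives a limit of the assay and not a number: the limit of > 100000 nM in this assay, at which 1 of the 4 values shown sits.

As far as these compounds go, it remains open whether 2-methylphenyl, or a methoxy group or an amine in place of the methyl, would give a number as low as that of compound 4. Compound 2 and compound 3 differ from compound 4 in more than one place, so they cannot settle this.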